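The compounds below may be only part of what the source reports. "The series", "measured", "known", "first", "only" and "open" are said of these compounds alone.

Of the compounds shown here, three of one series have so far been measured in an assay on HEK293 cells for negative allosteric modulation of metabotropic glutamate receptor 5 (Homo sapiens), read by FLIPR, with a stated time of 1 h; on this read-out higher numbers stand for weaker inhibition and lower numbers for stronger inhibition. Compound 1 `O=C1c2sc(C#Cc3ccccc3)nc2CN1C1CC1` gives 23 nM in this assay, compound 3 `Fc1cccc(C#Cc2nc3c(s2)CN(C2CCC2)CC3)c1` gives 200 nM, and compound 2 `CC(C)CN1CCc2nc(C#Cc3ccccc3)sc2C1` gives 650 nM. Compound 2 therefore stands highest of the three numbers and is the weakest inhibitor among them: its nearest neighbour is compound 3, whose number lies lower by a margin beyond the usual scatter, and compound 1 lies further below still.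

The next compound to be measured is compound 4 `O=C(C1CCCC1)N1CCc2nc(C#Cc3ccccc3)sc2C1`. It differs from compound 2 in a single place: cyclopentylcarbonyl in place of isobutyl on an amine nitrogen in a ring. For the measured compounds named here, no pair of measured compounds differs in exactly this way, so the size of the step can only be guessed. Going by the values given here, because compound 1, the only measured compound that also contains a carbonyl group, gives 23 nM in this assay, a move toward a lower number seems more likely than a move upward, and the step from compound 2 to compound 4 is expected to be a 4.3-fold lower number from compound 2 to compound 4 (0.64 log units; beyond the scatter), which is larger than the scatter. On that basis compound 4 is estimated to give about 150 nM in this assay, with a plausible range from 40 nM to 600 nM.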

Compound 4, half-maximal inhibitory concentration: > 10000 nM
Compound 4 ended at the assay's limit; the forecaster's own chance of this, stated with the estimate: 5%; at least 66-fold (1.82 log units) between middle value and limit.
By their numbers in this assay, from the lowest: compound 1; then compound 3; then compound 2. At a limit, above all of these: compound 4.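

On the amine nitrogen in a ring, one change is enough to carry a compound out of the measurable range: in this assay, cyclopentylcarbonyl in place of isobutyl gives an at least 15-fold higher number from compound 2 to compound 4 (1.18 log units; beyond the scatter), a large step. From the compounds shown here alone, for compound 4 the value is a limit of the assay and not a number, so the true size of this step stays unknown: the limit of > 10000 nM in this assay, at which 1 of the 4 values shown sits. The change brings in a five-membered ring of carbon and a carbonyl together, so this single step cannot assign the loss to either of them, and nothing shown gives a reason for it.

For the compounds shown here, compound 1 and compound 3 each differ from compound 2 and from compound 4 in more than one place, so no steps to them can be read, and the value of compound 1 says nothing direct about a carbonyl at this nitrogen. Still open, going by these compounds, is how this nitrogen would respond to cyclopentylmethyl, which keeps the ring without the carbonyl, or to isobutyryl, which keeps the carbonyl without the ring.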